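The source may report more compounds than this note shows. Statements on the series, on what has been measured and on what is new or still open speak of the compounds shown alone.

Measured compounds in an ADME assay on microsomes from liver (Homo sapiens) for pharmacokinetics; a lower number here means slower removal, a higher number faster removal of the compound:
- compound 3 `Cc1nn(C)cc1Nc1nc(N)c2c(C#N)c(N3CCC[C@H]3C)n(C)c2n1`: 70 mL/min/kg
- compound 1 `Cc1c(Nc2nc(N)c3c(C#N)c(N4CCC[C@H]4C)n(C)c3n2)cnn1CC(C)(C)O`: 30 mL/min/kg
- compound 2 `Cc1c(Nc2nc(N)c3c(C#N)c(N4CCC[C@H]4C)n(C)c3n2)cnn1[C@@H]1CCOC1`: 28.3 mL/min/kg

Compound 3 gives the highest of the three numbers in this assay. Compound 1 sits a 1.1-fold lower number from compound 1 to compound 2 (0.03 log units; within the scatter) apart from compound 2, a step within the scatter; both sit beyond the scatter below compound 3.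

Compound 4 `C[C@@H]1CCCN1c1c(C#N)c2c(N)nc(Nc3cn(C)nc3C(F)(F)F)nc2n1C` is the next compound in the series and is to be measured in this assay. It differs from compound 3 in one place: trifluoromethyl in place of methyl on an aromatic carbon. Among the compounds with values here, the only measured step, from compound 1 to compound 2, concerns a change on an aromatic nitrogen of the same ring and was within the scatter; no measured step exchanges a group on an aromatic carbon, so there is no direct precedent for this change. Compounds 1 and 2, which carry larger groups than compound 3 at the ring nitrogen, both give lower numbers, but that is a different position and cannot be read as a rule for the present change.

Within the data shown here, with no bearing step, a small step is expected, if anything downward from compound 3, and the expected step from compound 3 to compound 4 is a 1.4-fold lower number from compound 3 to compound 4 (0.15 log units; within the scatter). For compound 4 in this assay the estimate is 50 mL/min/kg, with a range from 25 mL/min/kg to 100 mL/min/kg.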

Compound 4, clearance: 33.3 mL/min/kg
The estimate for compound 4 lay 1.5-fold (0.18 log units) above the measured number; the range from low to high includes it.
By their numbers in this assay, from the lowest: compounds 2, 1 and 4 (each within the scatter of the next); then compound 3.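

In this assay, trifluoromethyl in place of methyl on the aromatic carbon gives a 2.1-fold lower number from compound 3 to compound 4 (0.32 log units; beyond the scatter), a modest step and the only one shown that exchanges a group on an aromatic carbon. Within the data shown here, the one earlier step, a 1.1-fold lower number from compound 1 to compound 2 (0.03 log units; within the scatter), concerned a group on an aromatic nitrogen of the same ring, so this aromatic carbon is the only place in the ring where a single exchange has been seen to move the number beyond the scatter. Nothing measured here accounts for the step, which stands as an observation on one pair of compounds.

From the compounds shown here alone, whether other groups on this carbon, such as ethyl, cyclopropyl, chlorine or methoxy, would give a step of similar size or direction remains open, and a single exchange sets no trend. Also open, going by these compounds, is whether trifluoromethyl in place of methyl gives a comparable step when the ring nitrogen carries 2-hydroxy-2-methylpropyl or oxolan-3-yl rather than methyl.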